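One More Carbon on the Chain of Compound 3

A few compounds are considered here, and "the series" means these few. Any claim that something is new, unique, unknown or untested is made for them only; others in the source may bear on it.

In a functional assay on MCF7 cells (Homo sapiens) for antiproliferative activity, with a stated time of 5 days (on this read-out lower numbers stand for stronger inhibition and higher numbers for weaker inhibition), compound 3 (`CCCCCc1ccc2[nH]c(-c3ccc(C(F)(F)F)cc3)c(C=C(C#N)C#N)c2c1`) gives 100 nM and sits close to compound 2 (`CCCCc1ccc2[nH]c(-c3ccc(C(F)(F)F)cc3)c(C=C(C#N)C#N)c2c1`) at 150 nM within the scatter. Compound 1 (`CCCCCCc1ccc2[nH]c(-c3ccc(OC)cc3)c(C=C(C#N)C#N)c2c1`) reads clearly lower at 25 nM than both of them.

Compound 4 (`CCCCCCc1ccc2[nH]c(-c3ccc(C(F)(F)F)cc3)c(C=C(C#N)C#N)c2c1`) differs from compound 3 by methyl in place of hydrogen on a saturated chain carbon, five bonds along the chain from an aromatic carbon and by nothing else. This extends the saturated chain by one carbon, with methyl in place of hydrogen five bonds along the chain from an aromatic carbon.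

Going by the values given here, only one measured step bears directly on this change. Methyl in place of hydrogen four bonds along the chain from an aromatic carbon gave a 1.5-fold lower number from compound 2 to compound 3 (0.18 log units; within the scatter) and so stayed within the scatter. One step of that size establishes no firm trend, so no change beyond the scatter is expected in this assay and at most a slight drift in the same direction. The expected step is a 1.3-fold lower number from compound 3 to compound 4 (0.12 log units; within the scatter) and would be too small to read with confidence. For compound 4 the estimated value is 75 nM (expected range 35 nM to 170 nM).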

Compound 4, half-maximal inhibitory concentration: 68 nM
The estimate for compound 4 lay 1.1-fold (0.04 log units) above the measured number; the measured number falls inside the stated range.
By their numbers in this assay, from the lowest: compound 1; then compounds 4, 3 and 2 (each within the scatter of the next, the first and the last beyond it).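

In this assay, one more carbon on the chain again gives a step too small to read alone (a 1.5-fold lower number from compound 3 to compound 4 (0.17 log units; within the scatter)), but the two added carbons together give the first chain-length difference that clears the scatter (a 2.2-fold lower number from compound 2 to compound 4 (0.34 log units; beyond the scatter)). Going by these compounds alone, with the chain now the same in both compounds, the group on the aromatic ring can also be compared directly for the first time, and trifluoromethyl in place of methoxy gives a modest step beyond the scatter (a 2.7-fold higher number from compound 1 to compound 4 (0.43 log units; beyond the scatter)). No measurement shown explains either difference.

The compounds shown leave open whether a longer chain would continue this drift or reverse it. They also leave open how a chain carrying an amine or a carboxylic acid would read in this assay.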